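The source may hold more compounds than are shown below. What is called first, only, known or untested is meant among the compounds shown, and "the series" means these compounds.

Measured in a functional assay on MCF7 cells (Homo sapiens) for cytotoxicity, read by MTT assay, with a stated time of 72 h; a higher number here means a weaker inhibitor, a lower number a stronger inhibitor:

- Compound 1 `COc1cc(/C=C/C(=O)Nc2cc3c(Nc4ccc(F)c(Cl)c4)ncnc3cc2O[C@H]2CCOC2)cc(OC)c1OC`: 28400 nM
- Compound 2 `COc1ccc(OC)c(/C=C/C(=O)Nc2cc3c(Nc4ccc(F)c(Cl)c4)ncnc3cc2O[C@H]2CCOC2)c1`: 36300 nM
- Compound 3 `O=C(/C=C/c1ccccc1[N+](=O)[O-])Nc1cc2c(Nc3ccc(F)c(Cl)c3)ncnc2cc1O[C@H]1CCOC1`: 28400 nM

In this assay, compound 3 matches compound 1 at the digits reported, and compound 2 lies within the scatter of both. The three compounds therefore cannot be ranked on these numbers.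

The next compound, compound 4 `COc1cc(/C=C/C(=O)Nc2cc3c(Nc4ccc(F)c(Cl)c4)ncnc3cc2O[C@H]2CCOC2)cc(OC)c1`, has not yet been measured. The change from compound 3 is 3,5-dimethoxyphenyl in place of 2-nitrophenyl on a double-bonded chain carbon bound to a double-bonded chain carbon.

Within the data shown here, three measured steps bear on this change, since each exchanges one substituted phenyl group for another at the same place: no change at the digits printed from compound 1 to compound 3 (within the scatter), a 1.3-fold lower number from compound 2 to compound 3 (0.11 log units; within the scatter) and a 1.3-fold higher number from compound 1 to compound 2 (0.11 log units; within the scatter). None of them goes beyond the scatter, and they cover 2-nitrophenyl, 2,5-dimethoxyphenyl and 3,4,5-trimethoxyphenyl. Among the measured compounds shown here, the 3,5-dimethoxyphenyl group itself has no measurement yet, so this remains an inference from three compounds only.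

On that evidence, no step beyond the scatter is expected in this assay, and no direction can be favoured. The expected step is a 1.1-fold higher number from compound 3 to compound 4 (0.02 log units; within the scatter). For compound 4 the estimated value is 30000 nM, with an expected range from 15000 nM to 60000 nM.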

Compound 4, half-maximal inhibitory concentration: 30300 nM
Compound 4: the middle estimate sits 1.0-fold (0.00 log units) below what was measured, within the range that was stated.
By their numbers in this assay, from the lowest: compounds 1, 3, 4 and 2 (each within the scatter of the next).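

In this assay, 3,5-dimethoxyphenyl in place of 2-nitrophenyl on a double-bonded chain carbon bound to a double-bonded chain carbon gives a 1.1-fold higher number from compound 3 to compound 4 (0.03 log units; within the scatter) and, in place of 2,5-dimethoxyphenyl at the same spot, gives a 1.2-fold lower number from compound 2 to compound 4 (0.08 log units; within the scatter) here, so a fourth substituted phenyl group joins the others without separating from any of them. Among these compounds, the new compound also supplies the first exchange confined to a single substituent on this phenyl ring: hydrogen in place of methoxy on an aromatic carbon gives a 1.1-fold higher number from compound 1 to compound 4 (0.03 log units; within the scatter) and thus shows that, in this one pair, losing that methoxy group does not carry the number beyond the scatter. No accompanying measurement offers any explanation of why these four numbers stay together.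

From the compounds shown here alone, whether an amine or a carboxylic acid on this phenyl ring, or a plain unsubstituted phenyl, would move the number beyond the scatter remains open, as does the effect of a longer chain in place of the ethenyl link. All four compounds also share one core, so these results say nothing about changes made there.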